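Swapping the aryl group on the triazinedione nitrogen

The compounds below may be only part of what the source reports. "The series", "measured", "known", "first", "only" and "open" are said of these compounds alone.

Compound 2 `Cn1c(=O)c(C(=O)Nc2ccc(Oc3ccncc3-c3cccnc3)c(F)c2)nn(-c2cccc(C(F)(F)F)c2)c1=O` is the parent for this step. In a functional assay on HT-29 cells (Homo sapiens) for cytotoxicity, read by MTT assay, with a stated time of 72 h (a higher number here means a weaker inhibitor, a lower number a stronger inhibitor), compound 2 gives 510 nM, the lowest of the two numbers obtained so far; its nearest neighbour is compound 1 `Cn1c(=O)c(C(=O)Nc2ccc(Oc3ccncc3-c3cccnc3)c(F)c2)nn(-c2ccccc2F)c1=O`, which in this assay gives 2100 nM. Going by the values given here, the only step that bears on the present change is a 4.1-fold lower number from compound 1 to compound 2 (0.61 log units; beyond the scatter), a change of the aryl group on the same aromatic nitrogen. Compound 3 `Cn1c(=O)c(C(=O)Nc2ccc(Oc3ccncc3-c3cccnc3)c(F)c2)nn(-c2c(Cl)cccc2Cl)c1=O` carries 2,6-dichlorophenyl in place of 3-(trifluoromethyl)phenyl on an aromatic nitrogen. Among the compounds with values here, both chlorines now sit flanking the ring attachment, a substitution pattern no measured compound shows, so the one step in hand gives only a loose guide. The account therefore expects a number for compound 3 that lies close to or somewhat above that of compound 2, with a 2.0-fold higher number from compound 2 to compound 3 (0.29 log units; within the scatter) as the expected shift. The estimate for compound 3 in this assay is 1000 nM, with a range from 300 nM to 3500 nM.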

Compound 3, half-maximal inhibitory concentration: 780 nM
Estimate against measurement, compound 3: 1.3-fold (0.11 log units) above; the range from low to high includes it.
By their numbers in this assay, from the lowest: compounds 2 and 3 (each within the scatter of the next); then compound 1.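

On this aromatic nitrogen, 2,6-dichlorophenyl in place of 3-(trifluoromethyl)phenyl gives a 1.5-fold higher number from compound 2 to compound 3 (0.18 log units; within the scatter) in this assay, so these two aryl groups, with their different substitution patterns, cannot be told apart here. The 2-fluorophenyl group is the one that stands apart: 2,6-dichlorophenyl in its place gives a 2.7-fold lower number from compound 1 to compound 3 (0.43 log units; beyond the scatter), a second step beyond the scatter in the same direction as a 4.1-fold lower number from compound 1 to compound 2 (0.61 log units; beyond the scatter). Nothing measured here accounts for why these aryl groups match or differ. The compounds shown leave open whether an aryl group is needed on this nitrogen at all, or whether a cyclohexyl ring or a simple alkyl chain would serve as well. They also leave open how an unsubstituted phenyl, a pyridyl ring or a phenyl ring carrying a single chlorine would compare.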